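The source may report more compounds than this note shows. Statements on the series, on what has been measured and on what is new or still open speak of the compounds shown alone.

In a functional assay on MDA-MB-231 cells (Homo sapiens) for antiproliferative activity, read by MTT assay, with a stated time of 48 h (on this read-out higher numbers stand for weaker inhibition and lower numbers for stronger inhibition), compound 1 `COc1ccc(N(C)c2ccnc(Cl)n2)cc1Cl` gives 1380 nM, compound 2 `COc1ccc(N(C)c2ccnc(Cl)n2)cc1[N+](=O)[O-]` gives 8120 nM and compound 3 `COc1ccc(N(C)c2ccnc(Cl)n2)cc1OCCBr` gives 6620 nM. The three numbers fall on two levels. Compound 3 shares the upper level with the nitro analogue, as the comparison shows: a 1.2-fold lower number from compound 2 to compound 3 (0.09 log units; within the scatter). The chloro analogue stands clearly apart, with a 4.8-fold higher number from compound 1 to compound 3 (0.68 log units; beyond the scatter) and, on the nitro side, a 5.9-fold higher number from compound 1 to compound 2 (0.77 log units; beyond the scatter).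

Compound 4 `COc1ccc(N(C)c2ccnc(Cl)n2)cc1OCCCCCBr` keeps the shared core and lengthens the side chain of compound 3: 3-bromopropyl in place of bromo on a saturated chain carbon, two bonds along the chain from an oxygen on an aromatic ring. The same difference reads as 2-bromoethoxy to (5-bromopentyl)oxy.

For the measured compounds named here, no measured pair isolates a change in chain length, so the evidence is only indirect. The closest guides are the two swaps that install the 2-bromoethoxy group on an aromatic carbon. One of these, a 1.2-fold lower number from compound 2 to compound 3 (0.09 log units; within the scatter), stayed within the scatter, and the other, a 4.8-fold higher number from compound 1 to compound 3 (0.68 log units; beyond the scatter), was modest. Both replaced a whole group, whereas here the oxygen link and the terminal bromo are kept, so a large move in this assay seems unlikely, and the data give no firm direction. The expected change is a 1.3-fold lower number from compound 3 to compound 4 (0.12 log units; within the scatter), which is estimated to remain within the scatter. For compound 4 the estimated value is 5000 nM, with an expected range from 1800 nM to 13000 nM.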

Compound 4, half-maximal inhibitory concentration: > 10000 nM
Compound 4: no number, only a limit (the forecaster's own chance of this, stated with the estimate: 5%); middle value at least 2.0-fold (0.30 log units) away from the limit.
By their numbers in this assay, from the lowest: compound 1; then compounds 3 and 2 (each within the scatter of the next). At a limit, above all of these: compound 4.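

In this assay compound 4 gives no number but only a limit of the assay: the limit of > 10000 nM in this assay, at which 1 of the 4 values shown sits. Placed on the same aromatic carbon as the chloro group, the (5-bromopentyl)oxy group stays clearly away from the chloro level, with an at least 7.2-fold higher number from compound 1 to compound 4 (0.86 log units; beyond the scatter), so the longer chain does not recover what the 2-bromoethoxy group had already given up against chloro. Against the two weaker compounds the limit provides only floors, an at least 1.5-fold higher number from compound 3 to compound 4 (0.17 log units; that floor lies within the scatter) and an at least 1.2-fold higher number from compound 2 to compound 4 (0.09 log units; that floor lies within the scatter), so adding 3-bromopropyl in place of bromo on the chain brings no lower number, while the true size of either step cannot be read.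

The compounds shown leave open whether the number climbs steadily along the chain or only at the longest length, which a (3-bromopropyl)oxy or (4-bromobutyl)oxy group would help to settle. They also leave open what the terminal bromo contributes, as every chain shown ends in it, and an amine or a carboxylic acid at that end would put this to the test.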